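The source may hold more compounds than are shown below. What is called first, only, known or untested is meant among the compounds shown, and "the series" means these compounds.

Of the compounds shown here, three built on one shared core have been measured in a functional assay on PANC-1 cells (Homo sapiens) for inhibition, read by MTT assay, with a stated time of 24 h; a lower number here means a stronger inhibitor, a higher number a weaker inhibitor. Compound 1 `CC1(C)[C@H]2CC[C@]1(C)N(Cc1cn(-c3cccc(Cl)c3)nn1)C(=O)C2` gives 260 nM in this assay. Compound 2 `CC1(C)[C@H]2CC[C@]1(C)N(Cc1cn(-c3ccc(Cl)cc3)nn1)C(=O)C2` gives 440 nM in this assay. Compound 3 `CC1(C)[C@H]2CC[C@]1(C)N(Cc1cn(-c3ccccc3C#N)nn1)C(=O)C2` gives 240 nM in this assay. Compound 2 has the highest of the three numbers, but its steps to the others are small: a 1.7-fold higher number from compound 1 to compound 2 (0.23 log units; within the scatter) and a 1.8-fold lower number from compound 2 to compound 3 (0.26 log units; within the scatter), so all three stand within the usual scatter of one another and no order among them can be claimed.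

Compound 4 `CC1(C)[C@H]2CC[C@]1(C)N(Cc1cn(-c3cccc(O)c3)nn1)C(=O)C2` has not yet been measured. It differs from compound 2 in one place: 3-hydroxyphenyl in place of 4-chlorophenyl on an aromatic nitrogen. Going by the values given here, the only measured step that bears on this is a 1.7-fold higher number from compound 1 to compound 2 (0.23 log units; within the scatter), which exchanged 3-chlorophenyl for 4-chlorophenyl and stayed within the scatter. Among the compounds with values here, no measured step exchanges chlorine for a hydroxyl group, so the data give no guide to that part of the change. The expectation is therefore no step beyond the scatter. Compound 4 is estimated to give 320 nM in this assay, with a range from 120 nM to 900 nM. This estimate means an expected 1.4-fold lower number from compound 2 to compound 4 (0.14 log units; within the scatter).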

Compound 4, half-maximal inhibitory concentration: 280 nM
Compound 4: middle estimate off by 1.1-fold (0.06 log units), on the high side; measured number inside the range.
By their numbers in this assay, from the lowest: compounds 3, 1, 4 and 2 (each within the scatter of the next).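

The clearest new reading is the direct exchange of chloro for hydroxy on an aromatic carbon: in this assay this gives a 1.1-fold higher number from compound 1 to compound 4 (0.03 log units; within the scatter), so adding a hydrogen-bond donor to the group on the aromatic nitrogen leaves the number within the scatter. The other two steps, a 1.6-fold lower number from compound 2 to compound 4 (0.20 log units; within the scatter) and a 1.2-fold higher number from compound 3 to compound 4 (0.07 log units; within the scatter), also stay within the scatter, so the four groups shown at this position cannot be told apart in this assay. No evidence is available that could explain this lack of separation.

From the compounds shown here alone, it remains open whether an amine or a carboxylic acid on the phenyl ring, or a longer chain in place of that ring, would produce a step beyond the scatter. The compounds shown also leave open whether the shared core would tolerate such changes elsewhere.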